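The compounds below may be only part of what the source reports. "The series", "measured", "known", "first", "only" and "open" are said of these compounds alone.

Measured so far in an in vitro ADME assay on microsomes from liver (Homo sapiens) for pharmacokinetics, read by LC-MS, with a stated time of 10 min, tested at 1 uM; a lower number here means slower removal, a higher number faster removal of the compound:
compound 1 `CN1C[C@H](C(=O)Nc2ccccc2)[C@@H](c2ccc(/C=C/C(=O)Nc3ccccc3N)cc2)C1` gives 7 mL/min/kg
compound 2 `CN1C[C@H](C(=O)Nc2ccc(F)cc2)[C@@H](c2ccc(/C=C/C(=O)Nc3ccccc3N)cc2)C1` gives 5 mL/min/kg
compound 3 `CN1C[C@H](C(=O)Nc2ccc(C#N)cc2)[C@@H](c2ccc(/C=C/C(=O)Nc3ccccc3N)cc2)C1` gives 1 mL/min/kg

Where compound 2 stands: its number cannot be told apart from that of compound 1, the step of a 1.4-fold lower number from compound 1 to compound 2 (0.15 log units; within the scatter) lying within the scatter, whereas the step of a 5.0-fold lower number from compound 2 to compound 3 (0.70 log units; beyond the scatter) lies beyond it, as does a 7.0-fold lower number from compound 1 to compound 3 (0.85 log units; beyond the scatter). Compound 3 is thus the only one of the three to sit apart.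

Compound 4 `CN1C[C@H](C(=O)Nc2ccc(C(F)(F)F)cc2)[C@@H](c2ccc(/C=C/C(=O)Nc3ccccc3N)cc2)C1` is not yet measured. It differs from compound 2 as follows: trifluoromethyl in place of fluoro on an aromatic carbon.

Going by the values given here, no measured step involves a trifluoromethyl group. The steps at this aromatic carbon are fluoro in place of hydrogen, which gave a 1.4-fold lower number from compound 1 to compound 2 (0.15 log units; within the scatter), and cyano in place of hydrogen or of fluoro, which gave a 7.0-fold lower number from compound 1 to compound 3 (0.85 log units; beyond the scatter) and a 5.0-fold lower number from compound 2 to compound 3 (0.70 log units; beyond the scatter). Only the cyano steps moved the number beyond the scatter. Whether trifluoromethyl follows fluoro or cyano cannot be read from three compounds, so the expected step of a 1.3-fold lower number from compound 2 to compound 4 (0.10 log units; within the scatter) is set near no change, with a range wide enough to admit a modest move either way. Compound 4 is estimated at 4 mL/min/kg, with a range from 1.5 mL/min/kg to 10 mL/min/kg.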

Compound 4, clearance: 6 mL/min/kg
Estimate against measurement, compound 4: 1.5-fold (0.18 log units) below, within the range that was stated.
By their numbers in this assay, from the lowest: compound 3; then compounds 2, 4 and 1 (each within the scatter of the next).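

In this assay, trifluoromethyl at this aromatic carbon, para to a large group, gives a 1.2-fold higher number from compound 2 to compound 4 (0.08 log units; within the scatter) and a 1.2-fold lower number from compound 1 to compound 4 (0.07 log units; within the scatter), so compound 4 cannot be told apart from the fluoro compound 2 or the unsubstituted compound 1, even though trifluoromethyl has 4 heavy atoms where fluoro has 1. With a 6.0-fold higher number from compound 3 to compound 4 (0.78 log units; beyond the scatter), the separation of compound 3 now holds against all three other compounds: among hydrogen, fluoro, trifluoromethyl and cyano at this carbon, only cyano gives a number that stands apart, and among these four groups the number does not follow heavy-atom count. No measurement shown here accounts for this separation.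

On these data alone, it remains open whether cyano is a lone case at this carbon or one of several groups that stand apart in the same way, since the set holds no amine, carboxylic acid, methoxy group or primary amide here. Going by these compounds alone, it is also open whether cyano would give a similar step on a different carbon of this ring, or on a core that differs from the one shared by these compounds.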